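A few compounds are considered here, and "the series" means these few. Any claim that something is new, unique, unknown or untested is made for them only; others in the source may bear on it.

Measured so far in an ADME assay on MRC5 cells (Homo sapiens) for inhibition, with a stated time of 72 h; a lower number here means that less compound is needed, a higher number that more compound is needed for the effect:

- compound 1, `COc1cccc(OC)c1C(=O)Nc1c[nH]nc1C(=O)NC1CCC1`: > 50000 nM, a limit of the assay and not a number
- compound 2, `CO[C@H]1CC[C@H](NC(=O)c2n[nH]cc2NC(=O)c2ccc(OC(F)F)cc2)CC1`: 2500 nM

Compound 1 stands only at the limit of > 50000 nM in this assay, at which 1 of the 2 values shown sits, so no number is known for it. Among the measured compounds shown here, compound 2 gives a number, but the two compounds differ in more than one place, and no step between them is counted.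

Compound 3, `COc1cccc(OC)c1C(=O)Nc1c[nH]nc1C(=O)NCc1ncccc1C`, is not yet measured. It differs from compound 1 by (3-methylpyridin-2-yl)methyl in place of cyclobutyl on an amide-type nitrogen, that is, cyclobutylamino becomes ((3-methylpyridin-2-yl)methyl)amino. For the measured compounds named here, nothing among the measured compounds shows what this change does in this assay, and compound 1 offers only a limit to start from. The step from compound 1 to compound 3 in this assay is therefore expected to be uncertain in direction; the step expected is an at least 1.6-fold lower number from compound 1 to compound 3 (0.22 log units; that floor lies within the scatter). Compound 3 is expected to give about 30000 nM, estimated within 5000 nM to 100000 nM, with a fair chance that only a limit is reported.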

Compound 3, half-maximal effective concentration: > 50000 nM
Compound 3 was reported as a limit (the forecaster's own chance of this, stated with the estimate: 45%); at least 1.6-fold (0.22 log units) between middle value and limit.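

In this assay, compound 1 and compound 3 are both reported only as limits and not as numbers, so no step between them can be read: the limit of > 50000 nM in this assay, at which 2 of the 3 values shown sit.

Going by these compounds, whether (3-methylpyridin-2-yl)methyl in place of cyclobutyl on the amide-type nitrogen changes the half-maximal effective concentration at all, and in which direction, remains open.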